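Dropping the Aromatic Group from a Ring Nitrogen

A few compounds are considered here, and "the series" means these few. Any claim that something is new, unique, unknown or untested is made for them only; others in the source may bear on it.

Of the compounds shown here, three sharing one core have been tested in a functional assay (brain) for inhibition, with Rattus norvegicus as the target; a lower number here means a stronger inhibitor, a higher number a weaker inhibitor. Compound 1 `Cc1c(C)c2c(c(C)c1O)CCC(C)(C(=O)N1CCN(c3ccc(Cl)cc3)CC1)O2` gives 800 nM. Compound 2 `Cc1c(C)c2c(c(C)c1O)CCC(C)(C(=O)NCCN(C)C)O2` gives 8700 nM. Compound 3 `COc1ccccc1N1CCN(CC2(C)CCc3c(C)c(O)c(C)c(C)c3O2)CC1` gives 1000 nM, the second highest number of the three: compound 1 sits within the scatter of it, while compound 2 lies well beyond the scatter, at a clearly higher number. Compound 4 `Cc1c(C)c2c(c(C)c1O)CCC(C)(CN1CCNCC1)O2` has not been measured. It differs from compound 3 in one place: hydrogen in place of 2-methoxyphenyl on an amine nitrogen in a ring. Among the compounds with values here, because compound 2, the only compound without such a six-membered aromatic ring, gives 8700 nM, the step of a 5.0-fold higher number from compound 3 to compound 4 (0.70 log units; beyond the scatter) is expected to weaken inhibition beyond the scatter. Compound 4 is therefore estimated at 5000 nM in this assay, within a range from 1500 nM to 15000 nM.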

Compound 4, half-maximal inhibitory concentration: 1000 nM
Beside the measured number, compound 4's estimate is 5.0-fold (0.70 log units) above it; measured number outside the range, below it.
By their numbers in this assay, from the lowest: compounds 1, 3 and 4 (each within the scatter of the next); then compound 2.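

In this assay the swap of 2-methoxyphenyl for hydrogen on the ring nitrogen gives no change at the digits printed from compound 3 to compound 4 (within the scatter) and so shows that, for this pair, inhibition does not depend on that aromatic group. A bare amine nitrogen in the ring does as well as the nitrogen carrying the large group. Nothing available explains why the number holds. Still open, from the compounds shown here alone, is whether a methyl, an acetyl or a benzyl group on this nitrogen would move the number in either direction.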